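The source may report more compounds than this note shows. Statements on the series, on what has been measured and on what is new or still open speak of the compounds shown alone.

In an assay on isolated protein for inhibition of Aromatase (Homo sapiens), read by fluorescence, using NADPH, with a stated time of 30 min, tested at 50 uM (on this read-out lower numbers stand for less inhibition and higher numbers for more inhibition at the one concentration tested (going by the name of the read-out)), compound 1 `CCCCCc1ccc(-c2cc3ccccc3[nH]2)cc1` gives 0%, the low end of the three numbers recorded for the series. In this assay compound 3 `O=[N+]([O-])c1ccc2[nH]c(-c3ccc(Cl)c(Cl)c3)cc2c1` gives 7.59%, a reading that stays within the usual scatter of compound 1, so the two cannot be told apart. In this assay compound 2 `Cn1c(-c2ccc(Cl)c(Cl)c2)cc2cc(N)ccc21` gives 42%, which lies beyond the scatter of compound 1. Among the compounds with values here, no step between two measured compounds that differ in one place has been recorded, so the size of any single change on this read-out is unknown.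

Compound 4 `FC(F)(F)Oc1ccc(-c2cc3ccccc3[nH]2)cc1` has not yet been measured. It differs from compound 1 by one change: trifluoromethoxy in place of pentyl on an aromatic carbon. Within the data shown here, compound 1 is the only measured compound that carries the shared core without a further group on it, and nothing in the recorded numbers shows what trifluoromethoxy in place of pentyl does here. The expected step is a number 5 percentage points higher from compound 1 to compound 4 (within the scatter), none beyond the scatter, since compound 1 gives 0% and nothing recorded points to a rise from the change. Compound 4 is therefore estimated at 5%, with a range from 0% to 25%.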

Compound 4, a percentage reported as inhibition, at one concentration (the size of the read-out at that concentration, not a potency): 1.86%
Compound 4: the middle estimate sits 3.1 percentage points above what was measured; the measured number falls inside the stated range.
By their numbers in this assay, from the lowest: compounds 1, 4 and 3 (each within the scatter of the next); then compound 2.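

In this assay, within the data shown here, trifluoromethoxy in place of pentyl, on an aromatic carbon of a six-membered aromatic ring of carbon only, gives a number 1.9 percentage points higher from compound 1 to compound 4 (within the scatter), the first step that can be read for a single change. At this position, a chain of carbon only and a group of the same heavy-atom count carrying oxygen and fluorine, with one hydrogen-bond acceptor, cannot be told apart. No measured finding bears on this result.

From the compounds shown here alone, whether an amine, a carboxylic acid or a longer chain at this position would give a step beyond the scatter remains open. Among these compounds, no step yet links compound 2, at 42%, to any other compound, so which of its features goes with that number is also open.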